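Methylating a Hydroxy Group on a Shared Amide Core

This account rests on a few compounds, and the source may have more. Where it says the series, first, only, none or still open, it means among the compounds named here.

Among the compounds with values here, compound 2 `O=C(NCCCCc1cccnc1)c1ccc(-c2cccc(O)c2)cc1` is one of three compounds measured so far in an assay (Canis lupus familiaris) for binding affinity to platelet-activating factor receptor (Homo sapiens), read by radioligand binding; on this read-out lower numbers stand for stronger inhibition and higher numbers for weaker inhibition. In this assay compound 2 gives 300 nM. Compound 1 `COc1ccc(-c2ccc(C(=O)NCCCCc3cccnc3)cc2OC)cc1OC` gives 300 nM, the same number at the digits shown, so these two stand together as the highest of the three values. Within the data shown here, compound 3 `COc1ccc(-c2ccc(C(=O)NCCCCc3cccnc3)cc2[N+](=O)[O-])cc1OC` gives 200 nM, and the single measured step, a 1.5-fold lower number from compound 1 to compound 3 (0.18 log units; within the scatter), stays within the scatter, so all three compounds sit within the usual spread of one another.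

Among the measured compounds shown here, compound 4 `COc1cccc(-c2ccc(C(=O)NCCCCc3cccnc3)cc2)c1` differs from compound 2 in a single place: methyl in place of hydrogen on an oxygen on an aromatic ring No measured step changes a hydroxy into a methoxy, so nothing directly tells how this change behaves; the one measured step, from compound 1 to compound 3, concerns a different group and was within the scatter. For the measured compounds named here, since every number so far lies close together, no step beyond the scatter is expected here, and the expected move is no change at the digits printed from compound 2 to compound 4 (within the scatter). Compound 4 is therefore estimated at 300 nM, with a range from 150 nM to 600 nM.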

Compound 4, half-maximal inhibitory concentration: 280 nM
For compound 4 the middle estimate is 1.1-fold (0.03 log units) above the measured one, within the range that was stated.
By their numbers in this assay, from the lowest: compounds 3, 4, 1 and 2 (each within the scatter of the next).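

Methyl in place of hydrogen on this oxygen on an aromatic ring is the first measured step of its kind, and in this assay it stays within the scatter (a 1.1-fold lower number from compound 2 to compound 4 (0.03 log units; within the scatter)). The pair therefore shows that, on this shared core, 3-hydroxyphenyl and 3-methoxyphenyl cannot be told apart by this read-out, so the hydrogen on this oxygen can be replaced by a methyl without a change beyond the scatter. Nothing available explains why the two numbers stay so close.

Still open, as far as these compounds go, is whether a larger group on this oxygen, such as an ethyl or a longer chain, would also stay within the scatter. From the compounds shown here alone, an amine or a carboxylic acid in place of the hydroxy group is equally open, and either could move the number in a way this single step cannot predict.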